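The source may report more compounds than this note shows. Statements on the series, on what has been measured and on what is new or still open speak of the compounds shown alone.

Measured compounds:

Compound 1, `CC(=O)O[C@@H]1[C@H](OC(C)=O)[C@@H](CN=[N+]=[N-])O[C@H]1n1cnc2c(N)nc(Cl)nc21`, with 141000 nM in an ADME assay on L6 cells (Rattus norvegicus) for inhibition, read by resazurin assay, with a stated time of 72 h; on this read-out higher numbers stand for weaker inhibition and lower numbers for stronger inhibition.
Compound 2, `CC(=O)NC[C@H]1O[C@@H](n2cnc3c(N)nc(Cl)nc32)[C@H](OC(C)=O)[C@@H]1OC(C)=O`, with 190000 nM in this assay.
Compound 3, `[N-]=[N+]=NC[C@H]1O[C@@H](n2cnc3c(N)nc(F)nc32)[C@H](O)[C@@H]1O`, with 3100 nM in this assay.

Compounds 1 and 2 share a core, and they differ by one change: acetamido in place of azido on a saturated chain carbon bound to a saturated ring carbon. That change gave a 1.3-fold higher number from compound 1 to compound 2 (0.13 log units; within the scatter), so the two values are not told apart by this measurement. Compound 3 stands apart from both: its value is the lowest of the three, and the difference between its core and the core of compound 1 is not broken down here.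

Compound 4, `CC(=O)NC[C@H]1O[C@@H](n2cnc3c(N)nc(F)nc32)[C@H](O)[C@@H]1O`, has not yet been measured in this assay. It is related to compound 3 by the same change that relates compound 1 to compound 2: acetamido in place of azido on a saturated chain carbon bound to a saturated ring carbon. The change sits at the same place in both pairs, and it is seen twice among the compounds shown.

Among the compounds with values here, the expectation for compound 4 therefore rests on the one measured instance of this change, the step of a 1.3-fold higher number from compound 1 to compound 2 (0.13 log units; within the scatter), which stayed within the scatter. Compound 4 is expected to stay close to compound 3, with a step of about a 1.3-fold higher number from compound 3 to compound 4 (0.11 log units; within the scatter). On that basis compound 4 is estimated at 4000 nM in this assay, most likely between 1500 nM and 12000 nM.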

Compound 4, half-maximal inhibitory concentration: 182000 nM
For compound 4 the middle estimate is 46-fold (1.66 log units) below the measured one; the measured number lies above the stated range.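

In this assay, within the data shown here, putting acetamido in place of azido on a saturated chain carbon bound to a saturated ring carbon gave a 59-fold higher number from compound 3 to compound 4 (1.77 log units; beyond the scatter), so the change did not carry over from one core to the other with the same size: the same change on two cores in this assay, a 1.3-fold higher number (0.13 log units; within the scatter) from compound 1 to compound 2 and a 59-fold higher number (1.77 log units; beyond the scatter) from compound 3 to compound 4, 44-fold (1.64 log units) apart, beyond the scatter of two such steps This shows that, for these two pairs, the step measured on the core of compound 1 was no guide to the step on the core of compound 3, and that azido and acetamido could not be told apart on the first core but could on the second. It does not show which feature of the cores lies behind the gap, as those cores differ in more than one place, chloro against fluoro and acetyl esters against free hydroxyl groups, and with one pair per core it gives no general rule for the series.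

The compounds shown leave open whether the halogen or the acetyl esters decides the size of the step, as no pair here separates the two. They also leave open how another group in the place of azido, such as an amine or a carboxylic acid, would read on the core of compound 3.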